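The source may report more compounds than this note shows. Statements on the series, on what has been measured and on what is new or still open speak of the compounds shown alone.

Of the compounds shown here, three built on a shared core have been measured in a functional assay on PC-12 cells (Rattus norvegicus) for cytotoxicity, read by MTT assay, with stated times of 2 h and 24 h, tested at 1 uM; on this read-out higher numbers stand for a stronger effect at the one concentration tested and lower numbers for a weaker effect. Compound 1 `COc1ccccc1-n1nc(-c2ccc(C(F)(F)F)cc2O)nc1-c1ccccc1O` gives 70.7% in this assay. Compound 2 `Oc1cc(C(F)(F)F)ccc1-c1nc(-c2ccccc2O)n(-c2cccc(C(F)(F)F)c2)n1` gives 71.5%. Compound 3 `Oc1cc(C(F)(F)F)ccc1-c1nc(-c2ccccc2O)n(-c2ccc(Cl)cc2Cl)n1` gives 69%. The three numbers sit close together: the step of a number 0.8 percentage points higher from compound 1 to compound 2 (within the scatter) and the step of a number 1.7 percentage points lower from compound 1 to compound 3 (within the scatter) both fall within the scatter, and so does the step of a number 2.5 percentage points lower from compound 2 to compound 3 (within the scatter). Compound 3 therefore stands among its two neighbours, with no separation from either that the assay could resolve.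

The next compound, compound 4 `Oc1cc(C(F)(F)F)ccc1-c1nc(-c2ccccc2O)n(-c2cc(F)cc(F)c2)n1`, differs from compound 3 in one place: 3,5-difluorophenyl in place of 2,4-dichlorophenyl on an aromatic nitrogen. Among the compounds with values here, every measured step so far has exchanged the group on that same aromatic nitrogen, and none of them, a number 0.8 percentage points higher from compound 1 to compound 2 (within the scatter), a number 1.7 percentage points lower from compound 1 to compound 3 (within the scatter) or a number 2.5 percentage points lower from compound 2 to compound 3 (within the scatter), moved the read-out beyond the scatter. Nothing in the three measured compounds suggests that a further exchange at this position should behave differently. The account therefore expects no step beyond the scatter for compound 4, and the step it estimates is a number 1 percentage points higher from compound 3 to compound 4 (within the scatter). In this assay compound 4 is estimated at 70%, with a range from 60% to 80%.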

Compound 4, a percentage reported as activity, at one concentration (the size of the read-out at that concentration, not a potency): 75.5%
Compound 4: the middle estimate sits 5.5 percentage points below what was measured; the range from low to high includes it.
By their numbers in this assay, from the lowest: compounds 3, 1, 2 and 4 (each within the scatter of the next).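

With a fourth group on the aromatic nitrogen, the position again shows no resolved effect in this assay: exchanging 2,4-dichlorophenyl for 3,5-difluorophenyl gives a number 6.5 percentage points higher from compound 3 to compound 4 (within the scatter) and so changes the halogen and its place on the phenyl ring without a step the assay can separate. The same holds when 3,5-difluorophenyl replaces the other two groups, with a number 4 percentage points higher from compound 2 to compound 4 (within the scatter) and a number 4.8 percentage points higher from compound 1 to compound 4 (within the scatter) as the steps, so all four substituted phenyl groups shown on this nitrogen remain within the scatter of one another. Nothing measured here bears on what lies behind these numbers.

Every group shown on this nitrogen is a substituted phenyl, so it remains open whether an amine, a carboxylic acid or a longer alkyl chain in that place would move the read-out beyond the scatter. The 2-hydroxyphenyl group and the trifluoromethyl-bearing hydroxyphenyl group stay the same throughout, which leaves their part in the read-out open, and a reading at one concentration does not give a potency for any of these compounds.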